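Hydrazone aryl change and Vero cytotoxicity in the series

This account rests on a few compounds, and the source may have more. Where it says the series, first, only, none or still open, it means among the compounds named here.

compound 1 `COc1ccc(/C=N/NC(=O)c2cnc3c(C(F)(F)F)cccc3c2N[C@@H](CSc2ccccc2)CC(=O)N(C)C)cc1` — "not determined" (no result reported)
compound 2 `CN(C)C(=O)C[C@H](CSc1ccccc1)Nc1c(C(=O)N/N=C/c2ccc(F)cc2)cnc2c(C(F)(F)F)cccc12` — > 62.5 ug/mL
compound 3 `CN(C)C(=O)C[C@H](CSc1ccccc1)Nc1c(C(=O)N/N=C/c2ccc(Br)s2)cnc2c(C(F)(F)F)cccc12` — > 62.5 ug/mL

In an ADME assay on Vero cells (Chlorocebus sabaeus) for cytotoxicity, read by MTT assay, with a stated time of 72 h (a lower number here means a stronger inhibitor, a higher number a weaker inhibitor), compound 1 gives "not determined" (no result reported). Compound 2 gives > 62.5 ug/mL, which is a limit of the assay. Compound 3 gives > 62.5 ug/mL, likewise a limit of the assay. The step that the two limits leave unreadable from compound 2 to compound 3 therefore cannot be read; compound 3 stands at the limit, as does compound 2, while compound 1 has no number at all.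

Compound 4 `COc1ccc(/C=N/NC(=O)c2cnc3c(C(F)(F)F)cccc3c2N[C@@H](CSc2ccccc2)CC(=O)N(C)C)cc1O` differs from compound 3 by 3-hydroxy-4-methoxyphenyl in place of 5-bromothiophen-2-yl on a carbon with a double bond to nitrogen. Among the compounds with values here, no measured step gives a size to lean on; the two measured values both sit at the limit (the limit of > 62.5 ug/mL in this assay, at which 2 of the 3 values shown sit). For compound 4 the step of a number no higher from compound 3 to compound 4 (the limit leaves the size open) is expected to stay within the scatter, with the result most likely reported again as a limit. The estimate for compound 4 in this assay is 62.5 ug/mL, in the range 40 ug/mL to 100 ug/mL.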

Compound 4, half-maximal inhibitory concentration: > 62.5 ug/mL
Compound 4 was reported as a limit; the forecaster's own chance of this, stated with the estimate: 80%; the middle value sits exactly at the limit.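

No step among compound 2, compound 3 and compound 4 can be read, as each value is a limit and not a number: the limit of > 62.5 ug/mL in this assay, at which 3 of the 4 values shown sit.

The compounds shown leave open whether any of these hydrazone aryl groups gives a readable value in this assay.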